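The compounds below may be only part of what the source reports. "The series", "measured", "known", "first", "only" and "open" are said of these compounds alone.

Compound 3, with the structure `O=c1oc2ccc(F)cc2n1Cc1ccc(Cl)cc1`, is the weakest of the three measured compounds: in an assay on HeLa cells for inhibition of Indoleamine 2,3-dioxygenase 1 (Homo sapiens), with a stated time of 24 h (on this read-out higher numbers stand for weaker inhibition and lower numbers for stronger inhibition), compound 3 gives 80800 nM. The unsubstituted parent, compound 1 `O=c1oc2ccccc2n1Cc1ccc(Cl)cc1`, gives 35000 nM in this assay, and the chloro analogue, compound 2 `O=c1oc2ccc(Cl)cc2n1Cc1ccc(Cl)cc1`, gives 6080 nM. The steps among them show that a substituent on the fused benzene ring matters: a 5.8-fold lower number from compound 1 to compound 2 (0.76 log units; beyond the scatter), while a 2.3-fold higher number from compound 1 to compound 3 (0.36 log units; beyond the scatter) and a 13-fold higher number from compound 2 to compound 3 (1.12 log units; beyond the scatter).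

Compound 4, with the structure `O=c1oc2ccc([N+](=O)[O-])cc2n1Cc1ccc(Cl)cc1`, differs from compound 3 in one place: nitro in place of fluoro on an aromatic carbon. Going by the values given here, no measured step involves a nitro group, so the expectation rests on what the ring substituents already seen have done. The fluoro group, the smallest of them, gave the weakest inhibition; the chloro group, which adds more to the ring, gave the strongest. The nitro group enters with three heavy atoms and two hydrogen-bond acceptors, so a drop in the number from compound 3, of modest size, is the estimate: a 6.7-fold lower number from compound 3 to compound 4 (0.83 log units; beyond the scatter). For compound 4 the expected value in this assay is therefore 12000 nM, within a range from 3000 nM to 50000 nM.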

Compound 4, half-maximal inhibitory concentration: 99400 nM
Compound 4: middle estimate off by 8.3-fold (0.92 log units), on the low side, outside the stated range (above it).
By their numbers in this assay, from the lowest: compound 2; then compound 1; then compounds 3 and 4 (each within the scatter of the next).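

In this assay the nitro group and the fluoro group give results that cannot be told apart at this place on the ring, with a 1.2-fold higher number from compound 3 to compound 4 (0.09 log units; within the scatter), even though the nitro group brings three heavy atoms and the fluoro group only one, so the heavy-atom count of these two groups does not separate them. The nitro compound also differs clearly from the chloro compound, with a 16-fold higher number from compound 2 to compound 4 (1.21 log units; beyond the scatter), and from the unsubstituted parent, with a 2.8-fold higher number from compound 1 to compound 4 (0.45 log units; beyond the scatter), which leaves chloro as the only one of the three substituents shown that gives a lower number than hydrogen does. Nothing available here explains what sets chloro apart from the other two groups.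

The compounds shown leave open whether this lower number belongs to chloro alone or would also appear with bromo, the next larger halogen, or with a small carbon group such as methyl. They also leave open how an amine, a methoxy group or a carboxylic acid would behave at this same place on the ring, and so how far the chloro result can be extended to other groups.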